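Bulkier imidazole on the piperazine linker: expected potency

This account rests on a few compounds, and the source may have more. Where it says the series, first, only, none or still open, it means among the compounds named here.

Measured compounds:
compound 1 `Cc1cc(CN2CCN(c3cccc4[nH]c(-c5ccc(C(C)(C)C)cc5)nc34)CC2)nn1C`: 83 nM
compound 2 `CCCCn1cnc(CN2CCN(c3cccc4[nH]c(-c5ccc(C(C)(C)C)cc5)nc34)CC2)c1C`: 46 nM
compound 3 `Cc1nc(CN2CCN(c3cccc4[nH]c(-c5ccc(C(C)(C)C)cc5)nc34)CC2)cn1C`: 10 nM

All three share one core and differ only in the small aromatic ring hung on the linker. In an assay on isolated protein for displacement of a labelled ligand from Gonadotropin-releasing hormone receptor (Homo sapiens) (a lower number here means a stronger inhibitor, a higher number a weaker inhibitor), compound 3 gives the lowest number of the three: the step of an 8.3-fold lower number from compound 1 to compound 3 (0.92 log units; beyond the scatter) and the step of a 4.6-fold lower number from compound 2 to compound 3 (0.66 log units; beyond the scatter) both lie beyond the scatter, while the step of a 1.8-fold lower number from compound 1 to compound 2 (0.26 log units; within the scatter) does not.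

Compound 4 `CCCn1c(CC)nc(C)c1CN1CCN(c2cccc3[nH]c(-c4ccc(C(C)(C)C)cc4)nc23)CC1` is the next step from compound 3. The change is 2-ethyl-4-methyl-1-propyl-1H-imidazol-5-yl in place of 1,2-dimethyl-1H-imidazol-4-yl on a saturated chain carbon bound to an amine nitrogen in a ring. The nearest comparison is the step of a 4.6-fold lower number from compound 2 to compound 3 (0.66 log units; beyond the scatter), where compound 2 carried a longer chain on the ring nitrogen and a methyl on the ring carbon bound to the linker, much as compound 4 does. Going the other way, from compound 3 toward a ring of that kind, a modest rise in the number is therefore expected, a 3.5-fold higher number from compound 3 to compound 4 (0.54 log units; beyond the scatter). Compound 4 is expected to give 35 nM, within a range of 12 nM to 100 nM.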

Compound 4, half-maximal inhibitory concentration: 57 nM
Compound 4: middle estimate off by 1.6-fold (0.21 log units), on the low side; measured number inside the range.
By their numbers in this assay, from the lowest: compound 3; then compounds 2, 4 and 1 (each within the scatter of the next).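

In this assay, the more heavily substituted imidazole raises the number again (a 5.7-fold higher number from compound 3 to compound 4 (0.76 log units; beyond the scatter)), so a second ring of this larger kind also fails to keep the low number of compound 3. Two other steps stay within the scatter (a 1.2-fold higher number from compound 2 to compound 4 (0.09 log units; within the scatter); a 1.5-fold lower number from compound 1 to compound 4 (0.16 log units; within the scatter)), which leaves compound 3 alone apart from the other three. Compound 1 goes against a simple size rule: it carries only methyl groups on its ring, as compound 3 does, yet it falls with the larger groups, and no measurement here explains the difference.

As far as these compounds go, the propyl, ethyl and methyl groups of compound 4 all arrive together, so which of them matters remains open. Also open, from the compounds shown here alone, is how this position would respond to an imidazole bearing an amine or a carboxylic acid.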